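Working notes: from compound 2 to compound 3

A few compounds are considered here, and "the series" means these few. Any claim that something is new, unique, unknown or untested is made for them only; others in the source may bear on it.

compound 1 `CCNc1ccc(NC(=O)c2cc(Cl)ccc2O)c(Cl)c1`: 30200 nM
compound 2 `CCCN(CCC)c1ccc(NC(=O)c2cc(Cl)ccc2O)c(Cl)c1`: 10700 nM
compound 3 `O=C(Nc1ccc(NCc2ccc(Cl)cc2)cc1Cl)c1cc(Cl)ccc1O`: not yet measured

In an ADME assay on A549 cells (Homo sapiens) for cytotoxicity, read by resazurin assay, with a stated time of 48 h (on this read-out lower numbers stand for higher toxicity in this test and higher numbers for lower toxicity in this test), compound 2 holds the lowest of the two numbers, with compound 1 nearest. The next change is (4-chlorobenzyl)amino in place of dipropylamino on an aromatic carbon and puts (4-chlorobenzyl)amino in place of dipropylamino on an aromatic carbon. Going by the values given here, only one measured step bears on it, a 2.8-fold lower number from compound 1 to compound 2 (0.45 log units; beyond the scatter) at that same place. Among the compounds with values here, no measured compound carries an aromatic ring in this group, so the guide is thin. A modest further fall is expected, and the estimated move is a 1.8-fold lower number from compound 2 to compound 3 (0.25 log units; within the scatter) in this assay as a working figure. For compound 3 the expected value is 6000 nM with an estimated range from 2000 nM to 18000 nM on this read-out.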

Compound 3, half-maximal cytotoxic concentration: 59700 nM
Compound 3: the middle estimate sits 10-fold (1.00 log units) below what was measured; the whole stated range lies below it.
By their numbers in this assay, from the lowest: compound 2; then compounds 1 and 3 (each within the scatter of the next).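

At this position in this assay, the fall seen with dipropylamino does not carry over to (4-chlorobenzyl)amino (a 5.6-fold higher number from compound 2 to compound 3 (0.75 log units; beyond the scatter)). Against the ethylamino group the change reads (a 2.0-fold higher number from compound 1 to compound 3 (0.30 log units; within the scatter)), so compound 1 and compound 3 cannot be told apart here, and only compound 2 stands apart from both. No measurement on hand accounts for this.

Still open, going by these compounds, is how a diethylamino group or an unsubstituted benzylamino group would read at this position. These compounds also cannot show whether the chlorine on the benzyl ring matters to the number.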